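This account rests on a few compounds, and the source may have more. Where it says the series, first, only, none or still open, it means among the compounds named here.

In an ADME assay on Vero cells (Chlorocebus sabaeus) for cytotoxicity, read by CellTiter-Glo, with a stated time of 72 h (on this read-out lower numbers stand for higher toxicity in this test and higher numbers for lower toxicity in this test), compound 1 `[O-][n+]1nc(NC2CCC2)[n+]([O-])c2ccccc21` gives 8.9 ug/mL and stands level with compound 3 `[O-][n+]1nc(NC2CCCCC2)[n+]([O-])c2ccccc21` at 8.9 ug/mL and within the scatter of compound 2 `[O-][n+]1nc(NC2CCCC2)[n+]([O-])c2ccccc21` at 10 ug/mL on these numbers. Compound 4 `[O-][n+]1nc(NC2CCC2)[n+]([O-])c2ccc(F)cc21` keeps the cyclobutyl group and differs from compound 1 by fluoro in place of hydrogen on an aromatic carbon in one place, with fluoro in place of hydrogen on an aromatic carbon. The measured steps of a 1.1-fold higher number from compound 1 to compound 2 (0.05 log units; within the scatter) and no change at the digits printed from compound 1 to compound 3 (within the scatter) both lie within the scatter, yet they concern the ring on nitrogen and not this aromatic carbon, so they bear on it only loosely. Among the measured compounds shown here, no measured step covers fluoro, and no step beyond the scatter is expected in this assay here. The expected step is a 1.1-fold lower number from compound 1 to compound 4 (0.05 log units; within the scatter) and no more than that. For compound 4 the estimated value is 8 ug/mL within an expected range from 4 ug/mL to 16 ug/mL for the coming measurement.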

Compound 4, half-maximal cytotoxic concentration: 1.6 ug/mL
Compound 4: middle estimate off by 5.0-fold (0.70 log units), on the high side, and the stated range ends above it.
By their numbers in this assay, from the lowest: compound 4; then compounds 1, 3 and 2 (each within the scatter of the next).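

In this assay, fluoro in place of hydrogen on an aromatic carbon gives a 5.6-fold lower number from compound 1 to compound 4 (0.75 log units; beyond the scatter) and so lies beyond the scatter, whereas the changes of the ring on nitrogen among compound 1, compound 2 and compound 3 all stayed within it. This aromatic carbon, meta to a fused ring and para to a fused ring, is thus a place where one change moves the number in this test. Nothing given here accounts for the step. On these data alone, whether chloro, methoxy or an amine on this carbon would act as fluoro does stays open, as does whether fluoro would have the same effect with cyclopentyl or cyclohexyl on the nitrogen.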